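The source may report more compounds than this note shows. Statements on the series, on what has been measured and on what is new or still open speak of the compounds shown alone.

Compound 2 `Cc1cc(-c2ccc(NC(=O)Nc3cccc(C(F)(F)F)c3)cc2)c2c(N)onc2n1` is the weaker of the two measured compounds in a functional assay on MCF7 cells (Homo sapiens) for antiproliferative activity, read by fluorescence, with a stated time of 72 h (a lower number here means a stronger inhibitor, a higher number a weaker inhibitor), where compound 2 gives 37400 nM. Its nearest neighbour, compound 1 `Cc1cccc(NC(=O)Nc2ccc(-c3cc(C)nc4noc(N)c34)cc2)c1`, gives 10500 nM in this assay. Within the data shown here, the only measured step, a 3.6-fold higher number from compound 1 to compound 2 (0.55 log units; beyond the scatter), changes one substituent on the outer ring of the urea. Compound 3 `Cc1cc(-c2ccc(NC(=O)Nc3ccc(Cl)c(C(F)(F)F)c3)cc2)c2c(N)onc2n1` keeps everything in compound 2 and adds one atom: chloro in place of hydrogen on an aromatic carbon. Among the measured compounds shown here, no measured pair shows what adding a chloro does, so the step from compound 1 to compound 2 is the only guide, and it concerns a different change. The expectation is therefore a step from compound 2 to compound 3 of a 1.2-fold lower number from compound 2 to compound 3 (0.10 log units; within the scatter) in this assay, within the usual scatter and with no clear direction. Compound 3 is estimated at 30000 nM in this assay, expected to fall between 12000 nM and 80000 nM.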

Compound 3, half-maximal inhibitory concentration: 28800 nM
Compound 3: the middle estimate sits 1.0-fold (0.02 log units) above what was measured; the range from low to high includes it.
By their numbers in this assay, from the lowest: compound 1; then compounds 3 and 2 (each within the scatter of the next).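

In this assay, chloro in place of hydrogen on the outer ring, ortho to a trifluoromethyl group and para to a large group, gives a 1.3-fold lower number from compound 2 to compound 3 (0.11 log units; within the scatter) and so does not separate the two compounds. Among these compounds, this is the first measured change at this position, and the earlier step, which swapped methyl for trifluoromethyl, could not show it. On a compound that already carries a trifluoromethyl group, this position takes one more heavy atom with no step beyond the scatter.

On these data alone, it remains open whether a different group here, such as a methoxy, an amine or a carboxylic acid, would give a step beyond the scatter, and whether chloro would do the same on compound 1, which carries methyl instead of trifluoromethyl. No other kind of measurement shown here bears on this result.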